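From Azide to Benzamide on a Shared Core

The compounds below may be only part of what the source reports. "The series", "measured", "known", "first", "only" and "open" are said of these compounds alone.

Of the compounds shown here, two of one series have been measured in a functional assay on HCT-116 cells (Homo sapiens) for cytotoxicity, read by MTT assay, with a stated time of 72 h; a lower number here means a stronger inhibitor, a higher number a weaker inhibitor. Compound 1, with the structure `NS(=O)(=O)c1cc(-c2nnc(CN3CCC(Cc4ccccc4)CC3)o2)c(Cl)cc1SCc1ccccc1`, gives 19000 nM in this assay. Compound 2, with the structure `[N-]=[N+]=NCc1nnc(-c2cc(S(N)(=O)=O)c(SCc3ccccc3)cc2Cl)o1`, gives 100000 nM in this assay, the highest of the two numbers; its nearest neighbour is compound 1, whose number is lower by a margin beyond the usual scatter. Compound 3, with the structure `NS(=O)(=O)c1cc(-c2nnc(CNC(=O)c3ccccc3)o2)c(Cl)cc1SCc1ccccc1`, has not yet been measured in this assay. It differs from compound 2 in one place: benzamido in place of azido on a saturated chain carbon bound to an aromatic carbon. Within the data shown here, no single-change step between measured compounds exists to calibrate this replacement, so only the two known values can guide an expectation. Because compound 1 gives 19000 nM with a larger group on the same saturated chain carbon, the change from azido to benzamido is expected to move the number downward. The step of a 3.3-fold lower number from compound 2 to compound 3 (0.52 log units; beyond the scatter) is expected to lie beyond the scatter. Compound 3 is therefore expected to give about 30000 nM in this assay, within a range from 8000 nM to 100000 nM.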

Compound 3, half-maximal inhibitory concentration: 42000 nM
The estimate for compound 3 lay 1.4-fold (0.15 log units) below the measured number; the measured number falls inside the stated range.
By their numbers in this assay, from the lowest: compound 1; then compound 3; then compound 2.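

With a single change at this position now on record in this assay, benzamido in place of azido on a saturated chain carbon bound to an aromatic carbon gives a 2.4-fold lower number from compound 2 to compound 3 (0.38 log units; beyond the scatter), a modest step. The entering group adds a six-membered aromatic ring of carbon only and a hydrogen-bond donor, so the position accepts a much larger group here without the number rising, but the step alone cannot assign the change to either feature. Compound 3 gives 42000 nM and compound 1 gives 19000 nM, so benzamido does not bring the number down to that of compound 1, which remains the lowest of the three. No measurement at hand accounts for the size or direction of this step.

The compounds shown leave open whether the aromatic ring or the amide accounts for the step, which a plain amine or an acetamido group on the same saturated chain carbon could help to separate. They also leave open how a carboxylic acid or a longer chain bearing the benzamido group would read in this assay.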